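Replacing the aryl group on an oxazole ketone inhibitor

This account rests on a few compounds, and the source may have more. Where it says the series, first, only, none or still open, it means among the compounds named here.

The measured compounds:
compound 1 `NS(=O)(=O)c1ccccc1-c1cnc(C(=O)CCCCCCc2ccccc2)o1`, 1500 nM
compound 2 `O=C(O)c1ccc(-c2cnc(C(=O)CCCCCCc3ccccc3)o2)cc1`, 60 nM
compound 3 `COC(=O)c1ccc(-c2cnc(C(=O)CCCCCCc3ccccc3)o2)nc1`, 3.5 nM

All three were tested in an assay (Rattus norvegicus) for inhibition of Fatty-acid amide hydrolase 1 (Homo sapiens); a higher number here means a weaker inhibitor, a lower number a stronger inhibitor. Compound 2, which carries a 4-carboxyphenyl group on the shared core, gives 60 nM and stands second highest of the three numbers. Its nearest neighbour is compound 3, whose value of 3.5 nM lies well below it, beyond the scatter. The furthest is compound 1, whose value of 1500 nM lies far above it, also beyond the scatter.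

The unmeasured compound 4 `CC(=O)c1cnc(C(=O)CCCCCCc2ccccc2)o1` differs from compound 2 in one place: acetyl in place of 4-carboxyphenyl on an aromatic carbon. For the measured compounds named here, no pair of measured compounds shows this exact step, so nothing in the set directly tells its size. The three measured values do show that the group on this aromatic carbon moves the number strongly in both directions, so a shift beyond the scatter would not be surprising.

The account expects the smaller acetyl group to give a weaker inhibitor than compound 2, with an estimated step of a 4.2-fold higher number from compound 2 to compound 4 (0.62 log units; beyond the scatter). For compound 4 in this assay the estimate is 250 nM, in a range from 50 nM to 1200 nM.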

Compound 4, inhibition constant: 2 nM
Compound 4: middle estimate off by 130-fold (2.10 log units), on the high side; the measured number lies below the stated range.
By their numbers in this assay, from the lowest: compounds 4 and 3 (each within the scatter of the next); then compound 2; then compound 1.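

Exchanging 4-carboxyphenyl for acetyl on the aromatic carbon next to the ring oxygen gives a 30-fold lower number from compound 2 to compound 4 (1.48 log units; beyond the scatter) in this assay, a large change that the earlier compounds could not show because none of their pairs formed a listed step. A six-membered aromatic ring in this group is therefore not needed for a low number, since compound 4, whose acetyl group has no ring and only 3 heavy atoms, gives 2 nM and stands within the scatter of compound 3 at 3.5 nM, whose group keeps a ring. Nothing measured here explains the size of this step.

The step from compound 2 to compound 4 changes the ring and the carboxylic acid together, so the compounds shown do not tell which of the two accounts for it; an unsubstituted phenyl group or a methyl ester on the same phenyl ring at this carbon would separate them. They also leave open whether the carbonyl of the acetyl group matters, which an ethyl group in its place would test.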